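A few compounds are considered here, and "the series" means these few. Any claim that something is new, unique, unknown or untested is made for them only; others in the source may bear on it.

Measured so far:
compound 1, `Nc1nc(NCc2ccccc2)nc(-c2ccc(F)cc2CO)n1`: 4.58
compound 2, `Nc1nc(NCc2ccccc2)nc(-c2cc(Cl)ccc2CO)n1`: 4.49
compound 3, `Nc1nc(NCc2ccccc2)nc(-c2c(Cl)cccc2CO)n1`: 4.43

In a functional assay on cells for positive allosteric modulation of G-protein coupled receptor 68 (Homo sapiens), read by a luciferase reporter and cAMP accumulation, with a stated time of 30 min, at pH 6.8 and pH 8.3, in the presence of a further agent that is not named here (a lower number here means a less potent compound, a higher number a more potent compound, by a factor of ten per unit of this negative logarithm), compound 1 holds the highest of the three numbers, yet its gaps to compound 2 and to compound 3 both lie within the usual scatter, so the three compounds cannot be placed in any order on this evidence. The next compound, compound 4, `CCOc1ccc(-c2nc(N)nc(NCc3ccccc3)n2)c(CO)c1`, differs from compound 1 in one place: ethoxy in place of fluoro on an aromatic carbon. No step between two measured compounds resembles this exchange, so nothing shown here predicts its size. Since the three measured numbers sit close together, the step from compound 1 to compound 4 is expected to be small and of uncertain direction, a number 0.02 log units higher from compound 1 to compound 4 (within the scatter). Compound 4 is therefore estimated at 4.6, with a range from 4.1 to 5.2.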

Compound 4, negative logarithm of the antagonist equilibrium constant: 4.37
Beside the measured number, compound 4's estimate is 0.23 log units above it; the range from low to high includes it.
By their numbers in this assay, from the lowest: compounds 4, 3, 2 and 1 (each within the scatter of the next).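

Ethoxy in place of fluoro on this aromatic carbon, meta to a hydroxymethyl group and para to a large group, gives a number 0.21 log units lower from compound 1 to compound 4 (within the scatter) in this assay. This position therefore took ethoxy, with its oxygen acceptor and its three heavy atoms, without a change that can be told from the scatter. No evidence here bears on this exchange.

The compounds shown leave open whether an amine, a carboxylic acid or a longer alkoxy chain on this carbon would give a step beyond the scatter. They also leave open whether ethoxy on another carbon of this ring would behave alike.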